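Thiazolidinone series in JAR cell growth inhibition

A few compounds are considered here, and "the series" means these few. Any claim that something is new, unique, unknown or untested is made for them only; others in the source may bear on it.

Measured compounds:
compound 1 `CCOC(=O)C1=C(Nc2ccccc2)S/C(=C\c2ccc([N+](=O)[O-])c(O)c2)C1=O` — 12700 nM
compound 2 `CCOC(=O)C1=C(Nc2ccccc2)S/C(=C\c2cccc(C(=O)O)c2)C1=O` — 11700 nM
compound 3 `CCOC(=O)C1=C(Nc2ccc(Br)cc2)S/C(=C\c2ccc[nH]2)C1=O` — 27000 nM

In a functional assay on JAR cells (Homo sapiens) for inhibition, read by MTT assay, with a stated time of 72 h (on this read-out lower numbers stand for stronger inhibition and higher numbers for weaker inhibition), compound 2 gives 11700 nM, the lowest of the three numbers. Compound 1 sits within the scatter of compound 2, so nothing separates the two. Compound 3, which carries a bromine on its aniline ring and a five-membered heteroaromatic ring in place of the substituted phenyl, lies beyond the scatter from compound 2 with a higher number, the only difference among the three that stands out.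

Compound 4 `CCOC(=O)C1=C(Nc2ccccc2)S/C(=C\c2cc3cccnc3[nH]2)C1=O` is not yet measured. It differs from compound 2 at one position: a group of 9 heavy atoms (7 carbon, 2 nitrogen; one five-membered aromatic ring with 1 hetero atom, one six-membered aromatic ring with 1 hetero atom) in place of a group of 9 heavy atoms (7 carbon, 2 oxygen; one six-membered aromatic ring of carbon only), on a double-bonded chain carbon bound to a double-bonded ring carbon. The shared core and the aniline are unchanged. Among the measured compounds shown here, no step between measured compounds covers such a change, and compound 3 combines two changes, so it offers no clean guide. Given that every measured compound sits in a narrow, weak band in this assay, the step from compound 2 to compound 4 is expected to be small, likely no larger than the scatter, with a slight tendency toward a higher number: a 1.3-fold higher number from compound 2 to compound 4 (0.11 log units; within the scatter). Compound 4 is accordingly estimated at 15000 nM, within 6000 nM to 40000 nM.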

Compound 4, half-maximal inhibitory concentration: 14400 nM
For compound 4 the middle estimate is 1.0-fold (0.02 log units) above the measured one; low and high end bracket the measured number.
By their numbers in this assay, from the lowest: compounds 2, 1, 4 and 3 (each within the scatter of the next, the first and the last beyond it).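

In this assay, among the compounds shown here, the first single-place comparison, at the double-bonded chain carbon bound to a double-bonded ring carbon, is a 1.2-fold higher number from compound 2 to compound 4 (0.09 log units; within the scatter). The exchange removes the 3-carboxyphenyl, with its carbon-only ring and 2 oxygen atoms, and brings in a two-ring group with 2 nitrogen atoms, one five-membered and one six-membered aromatic ring, while the two groups match in heavy atoms, hydrogen-bond donors and hydrogen-bond acceptors; at this position, then, this change of ring type and hetero atoms does not separate compound 2 from compound 4 on this read-out. No supporting measurement bears on this result.

Still open, on these data alone, is how the position reads with a group that differs more in size or ring content, such as a methyl group, a cyclohexyl ring or an amine in place of the carboxylic acid on the phenyl ring. The bromine on the aniline ring of compound 3 also remains unresolved, as it appears there only together with a change at the chain carbon.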